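A few compounds are considered here, and "the series" means these few. Any claim that something is new, unique, unknown or untested is made for them only; others in the source may bear on it.

Compound 1 `NS(=O)(=O)c1ccc(/N=C/c2c(Cl)c3ccccc3oc2=O)cc1` gives 580 nM in an ADME assay on cells (Macrophage, Homo sapiens) for cytotoxicity, read by microscopy and CCK-8 assay, with a stated time of 48 h (on this read-out higher numbers stand for lower toxicity in this test and lower numbers for higher toxicity in this test), the second highest of the three numbers in hand. Compound 2 `N=C(N)NS(=O)(=O)c1ccc(/N=C/c2c(Cl)c3ccccc3oc2=O)cc1` gives 620 nM, and a 1.1-fold higher number from compound 1 to compound 2 (0.03 log units; within the scatter). Compound 3 `Cc1cc(NS(=O)(=O)c2ccc(/N=C/c3c(Cl)c4ccccc4oc3=O)cc2)no1` gives 420 nM, and a 1.4-fold lower number from compound 1 to compound 3 (0.14 log units; within the scatter); between these two, a 1.5-fold lower number from compound 2 to compound 3 (0.17 log units; within the scatter). Compound 4 `Cc1ccc2oc(=O)c(/C=N/c3ccc(S(N)(=O)=O)cc3)c(Cl)c2c1` differs from compound 1 by methyl in place of hydrogen on an aromatic carbon. Within the data shown here, none of the measured steps touches that aromatic carbon: all three alter the sulfonamide nitrogen, and all three stay within the scatter, so they bear on compound 4 only by showing that the shared core has so far tolerated small changes without a step beyond the scatter. Compound 4 is therefore expected to give about 580 nM, within 300 nM to 1100 nM, meaning an expected step of no change at the digits printed from compound 1 to compound 4 (within the scatter).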

Compound 4, minimum cytotoxic concentration: 1200 nM
Compound 4: middle estimate off by 2.1-fold (0.32 log units), on the low side; the measured number lies above the stated range.
By their numbers in this assay, from the lowest: compounds 3, 1, 2 and 4 (each within the scatter of the next, the first and the last beyond it).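

In this assay, among these compounds, methyl in place of hydrogen on this aromatic carbon gives a 2.1-fold higher number from compound 1 to compound 4 (0.32 log units; beyond the scatter) and is the first step here beyond the scatter, whereas the three changes on the sulfonamide nitrogen all stayed within it. The number for the shared core therefore responds to a single added carbon at this position, in the direction of lower toxicity in this test. Nothing measured here accounts for this step. From the compounds shown here alone, whether a methoxy group or an amine at this carbon would move the number the same way stays open. So does whether methyl here would have the same effect on compound 2 or compound 3.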